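This account rests on a few compounds, and the source may have more. Where it says the series, first, only, none or still open, it means among the compounds named here.

Compound 1 `CCOC(=O)C1=Cc2ccccc2OC1(OCc1cn(CC(=O)Nc2ccc(C)cc2)nn1)C(F)(F)F` is the starting point. In a functional assay on HeLa cells (Homo sapiens) for inhibition, read by MTT assay, with a stated time of 24 h (on this read-out lower numbers stand for stronger inhibition and higher numbers for weaker inhibition), compound 1 gives 67400 nM, the only number shown, while the other value is the limit of > 150000 nM in this assay, at which 1 of the 2 values shown sits. Compound 2 `O=C(O)C1=Cc2ccccc2OC1(OCc1cc(-c2ccc([N+](=O)[O-])cc2)no1)C(F)(F)F` reaches only that limit, > 150000 nM, and so has no number of its own. Compound 3 `CCOC(=O)C1=Cc2ccccc2OC1(OCc1cn(-c2ccc(F)c([N+](=O)[O-])c2)nn1)C(F)(F)F` differs from compound 1 by 4-fluoro-3-nitrophenyl in place of ((4-methylphenyl)carbamoyl)methyl on an aromatic nitrogen. For the measured compounds named here, no measured pair shows what such a change does here, so the expected step from compound 1 to compound 3 is a 1.2-fold higher number from compound 1 to compound 3 (0.07 log units; within the scatter), none beyond the usual scatter. Compound 3 is therefore estimated at 80000 nM, with a range from 30000 nM to 200000 nM.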

Compound 3, half-maximal inhibitory concentration: 15600 nM
Compound 3: middle estimate off by 5.1-fold (0.71 log units), on the high side, and the stated range ends above it.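

This position on the five-membered aromatic ring is sensitive to its group in this assay: with 4-fluoro-3-nitrophenyl in place of ((4-methylphenyl)carbamoyl)methyl, the result is a 4.3-fold lower number from compound 1 to compound 3 (0.64 log units; beyond the scatter). The swap keeps a six-membered aromatic ring but removes the hydrogen-bond donor and changes several other features at once, so the step cannot be assigned to any single one. Nothing measured here explains the step.

As far as these compounds go, it remains open whether the fluorine or the nitro group matters more. Also unresolved is what a plain phenyl or a 4-aminophenyl group would give at this position.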